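The compounds below may be only part of what the source reports. "The series", "measured", "known", "first", "only" and "open" are said of these compounds alone.

Measured compounds:
- compound 1, `N#Cc1c(Nc2ccc(Cl)cc2)nc(SCC(=O)Nn2c(COc3ccc(Cl)cc3Cl)nc3ccccc3c2=O)nc1-c1ccccc1`: 51.9%
- compound 2, `N#Cc1c(Nc2ccc(Cl)cc2)nc(SCC(=O)Nn2c(COc3ccc(Cl)cc3Cl)nc3ccccc3c2=O)nc1-c1ccc(Cl)cc1`: 46.2%
- compound 3, `N#Cc1c(Nc2ccccc2)nc(SCC(=O)Nn2c(COc3ccc(Cl)cc3Cl)nc3ccccc3c2=O)nc1-c1ccc(O)cc1`: 90.4%

All three were tested in a functional assay on the whole organism (strain albino) for inhibition, with Rattus norvegicus as the target, read by paw edema, with stated times of 1 h and 0.5 h, at a dose of 100 mg/kg by the oral route; a higher number here means more inhibition at the dose given (going by the name of the read-out), a lower number less inhibition. Compound 3 stands highest of the three. Within the data shown here, its gap to compound 1 is beyond the usual scatter of repeated measurements, and its larger gap to compound 2 is beyond that scatter as well; compound 3 thus gives the highest number of the compounds measured so far. Compound 1 and compound 2 lie close to each other.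

The unmeasured compound 4, `N#Cc1c(Nc2ccc(Cl)cc2)nc(SCC(=O)Nn2c(COc3ccc(Cl)cc3Cl)nc3ccccc3c2=O)nc1-c1ccc(O)cc1`, is made from compound 3 by a single change: chloro in place of hydrogen on an aromatic carbon. The change sits on the anilino ring, turning it into a (4-chlorophenyl)amino group. Among the measured compounds shown here, one measured step bears on this: the same change, chloro in place of hydrogen on an aromatic carbon of the anilino ring, is what separates compound 1 from compound 2, and that step, a number 5.7 percentage points lower from compound 1 to compound 2 (within the scatter), stayed within the scatter. On that basis compound 4 is expected to stay near compound 3, with a step of a number 5.4 percentage points lower from compound 3 to compound 4 (within the scatter) that is estimated to be small and not beyond the scatter. Compound 4 is therefore estimated at 85%, within a range from 70% to 97%.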

Compound 4, a percentage reported as inhibition, in the whole organism at one dose (the size of the read-out at that dose, not a potency): 65.4%
The estimate for compound 4 lay 19.6 percentage points above the measured number, outside the stated range (below it).
By their numbers in this assay, from the lowest: compounds 2 and 1 (each within the scatter of the next); then compound 4; then compound 3.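

In this assay, chloro on the anilino group is not a harmless change when the hydroxy group is present, as shown by a number 25 percentage points lower from compound 3 to compound 4 (beyond the scatter). The hydroxy group still counts once the (4-chlorophenyl)amino group is in place, with a number 13.5 percentage points higher from compound 1 to compound 4 (beyond the scatter) when it replaces hydrogen and a number 19.2 percentage points higher from compound 2 to compound 4 (beyond the scatter) when it replaces chloro, so part of what it adds survives the loss. A chloro step therefore has no single size across these compounds, although in compound 2 the chloro enters on a different aromatic ring, not on the anilino group, so the two steps differ in place as well as in their surroundings: the same change on two cores in this assay, a number 5.7 percentage points lower (within the scatter) from compound 1 to compound 2 and a number 25 percentage points lower (beyond the scatter) from compound 3 to compound 4, 19.3 percentage points apart, beyond the scatter of two such steps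

The compounds shown leave open whether a fluoro, methyl or methoxy group at this place on the anilino group would lower the number as chloro does, or whether the step belongs to chloro alone. They also leave open how chloro on the anilino group would behave if an amine or a carboxylic acid stood where the hydroxy group sits.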